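Changing the amide side chain of compound 2

A few compounds are considered here, and "the series" means these few. Any claim that something is new, unique, unknown or untested is made for them only; others in the source may bear on it.

In an ADME assay on Caecum (Rattus norvegicus, strain Sprague-Dawley) for metabolic stability, read by LC-MS, tested at 10 uM (on this read-out lower numbers stand for a shorter-lived compound and higher numbers for a longer-lived compound), compound 2 `C[C@@H](N[C@H]1CCN(c2ccc(C(=O)NC(CO)(CO)CO)cc2)C1)c1cccc2ccccc12` reads > 12 h, which is a limit and not a number. Compound 1 `C[C@@H](N[C@H]1CCN(c2ccc(S(=O)(=O)NCC(=O)O)cc2)C1)c1cccc2ccccc12`, with its (carboxymethyl)sulfamoyl group, reads > 12 h, likewise a limit. Compound 3 `C[C@@H](N[C@H]1CCN(c2ccc(C(=O)N(C)[C@@H](O)[C@H](O)[C@H](O)[C@@H](O)CO)cc2)C1)c1cccc2ccccc12` gives 11 h. The measurements stop at the limit of > 12 h in this assay, at which 2 of the 3 values shown sit.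

Compound 4 `C[C@@H](N[C@H]1CCN(c2ccc(C(=O)NCCCN3CCC(C(=O)O)CC3)cc2)C1)c1cccc2ccccc12` carries 3-(4-carboxypiperidin-1-yl)propyl in place of 2-hydroxy-1,1-bis(hydroxymethyl)ethyl on an amide-type nitrogen, (3-(4-carboxypiperidin-1-yl)propyl in place of 2-hydroxy-1,1-bis(hydroxymethyl)ethyl on an amide-type nitrogen). Among the compounds with values here, two measured steps bear on this change. One is a step that the two limits leave unreadable from compound 1 to compound 2, and the other is an at least 1.0-fold lower number from compound 2 to compound 3 (0.03 log units; that floor lies within the scatter). Neither shows a readable change beyond the scatter, so none is expected here, and the expected step is a number no higher from compound 2 to compound 4 (the limit leaves the size open). For compound 4 the estimate is 12 h, with an expected range from 7 h to 20 h.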

Compound 4, half-life: > 12 h
Compound 4: only a limit was reported (the forecaster's own chance of this, stated with the estimate: 65%); the middle value lies on the limit itself.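

Within the data shown here, compound 2 and compound 4 both stop at a limit and not at a number, so no step between them can be read: the limit of > 12 h in this assay, at which 3 of the 4 values shown sit. Going by these compounds, how long compound 1, compound 2 and compound 4 actually last, and whether they truly differ, stays open.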